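The source may hold more compounds than are shown below. What is called first, only, known or untested is meant among the compounds shown, and "the series" means these compounds.

Measured compounds in an assay on HL-60 cells for agonist activity at vitamin D3 receptor (Homo sapiens), read by microscopy, with a stated time of 96 h; on this read-out higher numbers stand for an effect only at larger amounts of compound and lower numbers for an effect already at smaller amounts:
compound 1 `CCn1c(C(=O)NCCCN(C)C)ccc1C(CC)(CC)c1ccc(OCC(=O)C(C)(C)C)c(C)c1`: 96 nM
compound 2 `CCn1c(C(=O)N(C)CCC#N)ccc1C(CC)(CC)c1ccc(OCC(=O)C(C)(C)C)c(C)c1`: 9800 nM
compound 3 `CCn1c(C(=O)N(CCC#N)CCC#N)ccc1C(CC)(CC)c1ccc(OCC(=O)C(C)(C)C)c(C)c1`: 870 nM

On these numbers compound 3 stands second highest of the three: nearest to it is compound 1, with a 9.1-fold higher number from compound 1 to compound 3 (0.96 log units; beyond the scatter); furthest is compound 2, with an 11-fold lower number from compound 2 to compound 3 (1.05 log units; beyond the scatter). The new member is compound 4 `CCOC(=O)CC(C)OC(=O)c1ccc(C(CC)(CC)c2ccc(OCC(=O)C(C)(C)C)c(C)c2)n1CC`. It differs from compound 3 in one place: a group of 9 heavy atoms (6 carbon, 3 oxygen; no ring) in place of a group of 9 heavy atoms (6 carbon, 3 nitrogen; no ring), on a carbonyl carbon.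

Going by the values given here, none of the measured steps touches this kind of exchange; all three vary only what sits on the nitrogen attached to that carbonyl carbon. What they do show is that this region moves this assay strongly: a 100-fold higher number from compound 1 to compound 2 (2.01 log units; beyond the scatter), an 11-fold lower number from compound 2 to compound 3 (1.05 log units; beyond the scatter), and the more modest a 9.1-fold higher number from compound 1 to compound 3 (0.96 log units; beyond the scatter). A step beyond the scatter is therefore expected for compound 4, but its direction cannot be read from the shown compounds, so the range is set wide around a middle that is close to compound 3. For compound 4 the expected value is 1500 nM, between 150 nM and 15000 nM, which means an expected step of a 1.7-fold higher number from compound 3 to compound 4 (0.24 log units; within the scatter).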

Compound 4, half-maximal effective concentration: > 50000 nM
Compound 4: a limit, no number; the forecaster's own chance of this, stated with the estimate: 10%; middle value at least 33-fold (1.52 log units) from the limit.
By their numbers in this assay, from the lowest: compound 1; then compound 3; then compound 2. At a limit, above all of these: compound 4.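

In this assay compound 4 gives a limit and not a number: the limit of > 50000 nM in this assay, at which 1 of the 4 values shown sits. Up to here only the substituents on the amide-type nitrogen had varied; exchanging the nitrogen-bearing group of 9 heavy atoms for the oxygen-bearing one, on a carbonyl carbon whose other neighbour is an aromatic carbon, gives an at least 57-fold higher number from compound 3 to compound 4 (1.75 log units; beyond the scatter), which shows that the group's atom count alone does not hold the read-out. Going by these compounds alone, the change also goes past the highest number so far, with an at least 5.1-fold higher number from compound 2 to compound 4 (0.70 log units; beyond the scatter), and far from the lowest, with an at least 520-fold higher number from compound 1 to compound 4 (2.71 log units; beyond the scatter), so all three compounds with a nitrogen on this carbonyl carbon give numbers, while the one without it gives only a limit.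

The compounds shown leave open whether the oxygen on the carbonyl carbon or the ethyl ester chain accounts for this; an amide carrying the same chain would separate the two. From the compounds shown here alone, how a carboxylic acid or a plain methyl ester on that carbonyl carbon reads in this assay also stays open.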